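The compounds below may be only part of what the source reports. "The series", "measured", "known", "first", "only" and "open" are said of these compounds alone.

Compounds measured so far: compound 1 `CCn1c(-c2ccccc2)nc2c(NC3CCCCC3)ncnc21` with 9020 nM; compound 3 `CCn1c(-c2ccccc2)nc2c(NC3CCOC3)ncnc21` with 11500 nM; compound 2 `COc1ccc(-c2nc3c(NC4CCCC4)ncnc3n2C)cc1`.

In a functional assay on CHO cells for antagonist activity at adenosine receptor A2b (Homo sapiens), read by 33P incorporation, with a stated time of 20 min (on this read-out higher numbers stand for weaker inhibition and lower numbers for stronger inhibition), compound 1 gives the lowest of the two numbers shown. Compound 3 sits nearest to it, and the step of a 1.3-fold higher number from compound 1 to compound 3 (0.11 log units; within the scatter), which exchanges the group on the exocyclic amine, is within the scatter. Compound 2 gives only a limit of the assay, > 30000 nM, so it is not a number that can be set against the others.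

Compound 4 `CCCn1c(-c2ccccc2)nc2c(NC3CCCCC3)ncnc21` differs from compound 1 by methyl in place of hydrogen on a saturated chain carbon, two bonds along the chain from an aromatic nitrogen. Among the compounds with values here, none of the measured steps touches this chain: the only step measured, from compound 1 to compound 3, changes a different part of the molecule and was within the scatter. There is thus no measured ground for expecting a shift beyond the scatter in this assay in either direction.

Compound 4 is therefore estimated at 9000 nM, with a range from 3000 nM to 27000 nM, which means an expected step of a 1.0-fold lower number from compound 1 to compound 4 (0.00 log units; within the scatter).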

Compound 4, inhibition constant: 5310 nM
Compound 4: middle estimate off by 1.7-fold (0.23 log units), on the high side, and the stated range covers the measured number.
By their numbers in this assay, from the lowest: compounds 4, 1 and 3 (each within the scatter of the next, the first and the last beyond it). At a limit, above all of these: compound 2.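

The chain on the aromatic nitrogen had not been varied among the compounds with a readable number, and in this assay going from ethyl to propyl gives a 1.7-fold lower number from compound 1 to compound 4 (0.23 log units; within the scatter). This position therefore takes the added methyl without a step beyond the scatter, as was also the case for the exchange on the exocyclic amine, a 1.3-fold higher number from compound 1 to compound 3 (0.11 log units; within the scatter). Nothing among the compounds shown bears on the reason for the step from ethyl to propyl.

On these data alone, it remains open whether a longer chain such as butyl, a branched chain such as isopropyl, or a chain ending in an amine or a carboxylic acid would give a step beyond the scatter at this position. As far as these compounds go, it is also open whether propyl would read the same with oxolan-3-yl in place of cyclohexyl on the exocyclic amine.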